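Urea series on the shared core: propyl for phenyl

The compounds below may be only part of what the source reports. "The series", "measured", "known", "first", "only" and "open" are said of these compounds alone.

Compound 2 `O=C(Nc1ccccc1)Nc1ccc2c(c1)COC2=O` carries a phenylurea on the shared core. In a functional assay on cells (T-cell, Mus musculus) for inhibition (a higher number here means a weaker inhibitor, a lower number a stronger inhibitor), compound 2 gives 7090 nM, the lowest of the two numbers in hand. Compound 1 `O=C(/C=C/c1ccccc1)Nc1ccc2c(c1)COC2=O`, with a cinnamoyl amide in place of the urea, gives 7240 nM in this assay, within the scatter of compound 2, so no order between the two is claimed. Compound 3 `CN(C(=O)Nc1ccc2c(c1)COC2=O)c1ccccc1` reaches only the limit > 100000 nM in this assay. Among the compounds with values here, the step of an at least 14-fold higher number from compound 2 to compound 3 (1.14 log units; beyond the scatter) is thus bounded by the limit (the limit of > 100000 nM in this assay, at which 1 of the 3 values shown sits); it is the one measured change on the urea nitrogen.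

Compound 4 `CCCNC(=O)Nc1ccc2c(c1)COC2=O` differs from compound 2 by propyl in place of phenyl on an amide-type nitrogen. Within the data shown here, no measured step exchanges phenyl for an alkyl chain; the step from compound 2 to compound 3 touches the same nitrogen but by a different change, so it bears only loosely. The expected step is a 1.7-fold higher number from compound 2 to compound 4 (0.23 log units; within the scatter), with wide uncertainty. Compound 4 is estimated at 12000 nM, expected between 3000 nM and 50000 nM.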

Compound 4, half-maximal inhibitory concentration: 58100 nM
Beside the measured number, compound 4's estimate is 4.8-fold (0.68 log units) below it; the whole stated range lies below it.
By their numbers in this assay, from the lowest: compounds 2 and 1 (each within the scatter of the next); then compound 4. At a limit, above all of these: compound 3.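

In this assay, within the data shown here, the phenyl on this urea nitrogen proves to be more than a replaceable end group: an 8.2-fold higher number from compound 2 to compound 4 (0.91 log units; beyond the scatter) is the first measured exchange of the phenyl itself, and it lies beyond the scatter even though compound 4 keeps the amide hydrogen. Together with an at least 14-fold higher number from compound 2 to compound 3 (1.14 log units; beyond the scatter), this means that both single changes shown on this nitrogen, methyl on the nitrogen and propyl for phenyl, raise the number from compound 2, so loss of the amide hydrogen is not the only change here that costs activity. Nothing shown here gives a cause for the propyl step.

Going by these compounds, it remains open whether a saturated ring such as cyclohexyl or a longer chain such as hexyl would behave like propyl or like phenyl. A benzyl group, or a phenyl carrying chlorine or methoxy, would test how much of the aromatic ring this nitrogen needs.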